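Nitro for ethoxycarbonyl on the ester chain

This account rests on a few compounds, and the source may have more. Where it says the series, first, only, none or still open, it means among the compounds named here.

Among the measured compounds shown here, in an ADME assay on a cell-free system (plasma, Rattus norvegicus, strain Sprague-Dawley) for metabolic stability, with a stated time of 30 min, tested at 50 mg/mL (a lower number here means that less of the compound is left, a higher number that more of the compound is left), compound 2 `CCCc1nc(C(C)(C)O)c(C(=O)OCCCCCCC(=O)OCC)n1Cc1ccc(-c2ccccc2C2=NNNN2)cc1` gives 81.1%, the lower of the two numbers so far, and compound 1 `CCCc1nc(C(C)(C)O)c(C(=O)NCCCCCC[N+](=O)[O-])n1Cc1ccc(-c2ccccc2C2=NNNN2)cc1` gives 101%. For the measured compounds named here, only one measured step bears on the next change: a number 19.9 percentage points lower from compound 1 to compound 2 (beyond the scatter), modest and beyond the scatter. That step alters both the chain end and the link to the carbonyl, and the data do not separate the two. Compound 3 `CCCc1nc(C(C)(C)O)c(C(=O)OCCCCCC[N+](=O)[O-])n1Cc1ccc(-c2ccccc2C2=NNNN2)cc1` keeps the oxy link of compound 2 and takes the nitro chain end of compound 1: nitro in place of ethoxycarbonyl on a saturated chain carbon, six bonds along the chain from an oxygen next to a carbonyl group. With only a number 19.9 percentage points lower from compound 1 to compound 2 (beyond the scatter) as a guide, a small upward step, possibly within the scatter, is expected in this assay. The expected step is a number 4.9 percentage points higher from compound 2 to compound 3 (within the scatter). The estimate for compound 3 is 86%, with an expected range of 66% to 102%.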

Compound 3, percent of the compound remaining: 100%
Estimate against measurement, compound 3: 14 percentage points below; measured number inside the range.
By their numbers in this assay, from the lowest: compound 2; then compounds 3 and 1 (each within the scatter of the next).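

In this assay, the two changes combined in the earlier step can now be read apart. With the oxy link held, the chain-end change gives a number 18.9 percentage points higher from compound 2 to compound 3 (beyond the scatter), while with the nitro chain end held, (6-nitrohexyl)oxy in place of (6-nitrohexyl)amino gives a number 1 percentage points lower from compound 1 to compound 3 (within the scatter), so in these compounds the step beyond the scatter follows the chain end and not the link. No measured property in hand explains the chain-end step. Still open, from the compounds shown here alone, is whether this step is specific to ethoxycarbonyl, which a carboxylic acid, a primary amide or a nitrile at the same chain end would test. Also open, going by these compounds, are how a shorter or longer chain carrying the nitro group would behave, and whether ethoxycarbonyl on the amino link would match its behaviour on the oxy link.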